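Putting 4-fluoro-3-methylphenyl in place of 3,4-dihydroxyphenyl

The source may report more compounds than this note shows. Statements on the series, on what has been measured and on what is new or still open speak of the compounds shown alone.

Measured in a functional assay on KB cells (Homo sapiens) for antiproliferative activity, read by sulforhodamine B assay, with a stated time of 3 days; a lower number here means that less compound is needed, a higher number that more compound is needed for the effect:
- compound 1 `CCC1=C(O)c2c(oc(-c3ccc(CC)cc3)cc2=O)C(CC)(CC)C1=O` gives 21.9 uM
- compound 2 `CCCc1ccc(-c2cc(=O)c3c(o2)C(CC)(CC)C(=O)C(CC)=C3O)cc1` gives > 53 uM which is a limit of the assay
- compound 3 `CCC1=C(O)c2c(oc(-c3ccc(O)c(O)c3)cc2=O)C(CC)(CC)C1=O` gives 10 uM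

Compound 3 at 10 uM holds the lowest of the two numeric values in this assay and compound 1 is its nearest neighbour. Compound 4 `CCC1=C(O)c2c(oc(-c3ccc(F)c(C)c3)cc2=O)C(CC)(CC)C1=O` carries 4-fluoro-3-methylphenyl in place of 3,4-dihydroxyphenyl on an aromatic carbon next to the ring oxygen (4-fluoro-3-methylphenyl in place of 3,4-dihydroxyphenyl on an aromatic carbon). The same aromatic carbon was changed in two measured steps, a 2.2-fold lower number from compound 1 to compound 3 (0.34 log units; beyond the scatter) and an at least 5.3-fold lower number from compound 2 to compound 3 (0.72 log units; beyond the scatter) and both favour the 3,4-dihydroxyphenyl compound. The second of these rests on a limit. The alkyl chain also mattered (an at least 2.4-fold higher number from compound 1 to compound 2 (0.38 log units; beyond the scatter)). Compound 4 lacks the 3,4-dihydroxyphenyl group and most resembles compound 1 (21.9 uM) in having a phenyl ring without hydroxyl groups. A modest move to a higher number is therefore expected, an estimated 2.2-fold higher number from compound 3 to compound 4 (0.34 log units; beyond the scatter) in this assay overall. Compound 4 is estimated at 22 uM with an expected range of 9 uM to 50 uM in this assay as well.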

Compound 4, concentration for half-maximal effect: 40.5 uM
Compound 4: the middle estimate sits 1.8-fold (0.27 log units) below what was measured; measured number inside the range.
By their numbers in this assay, from the lowest: compound 3; then compounds 1 and 4 (each within the scatter of the next). At a limit, above all of these: compound 2.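

In this assay, a hydroxyl-free ring at this aromatic carbon next to the ring oxygen can be compared directly with the 3,4-dihydroxyphenyl group, and 4-fluoro-3-methylphenyl gives the higher number (a 4.1-fold higher number from compound 3 to compound 4 (0.61 log units; beyond the scatter)). The step from 4-ethylphenyl to 4-fluoro-3-methylphenyl (a 1.8-fold higher number from compound 1 to compound 4 (0.27 log units; within the scatter)) does not separate these two groups, whereas the step from 4-ethylphenyl to 3,4-dihydroxyphenyl (a 2.2-fold lower number from compound 1 to compound 3 (0.34 log units; beyond the scatter)) does separate those two, so compound 1 and compound 4 both stand apart from compound 3 without standing apart from each other. Compound 2 carries a limit and not a number: the limit of > 53 uM in this assay, at which 1 of the 4 values shown sits. The step that starts from this limit (an at least 1.3-fold lower number from compound 2 to compound 4 (0.11 log units; that floor lies within the scatter)) therefore cannot be read.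

Whether both hydroxyl groups are needed remains open, as 3-hydroxyphenyl and 4-hydroxyphenyl are not among the compounds shown. Going by these compounds, how an amine or a carboxylic acid on this phenyl ring would read in this assay also remains open.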